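Replacing benzyl with 3,4-dinitrophenyl on compound 1

The source may hold more compounds than are shown below. What is called first, only, known or untested is meant among the compounds shown, and "the series" means these compounds.

Measured so far in an ADME assay on HEK-293T cells (Homo sapiens) for cytotoxicity, read by CCK-8 assay, with a stated time of 48 h; on this read-out higher numbers stand for weaker inhibition and lower numbers for stronger inhibition:
Compound 1 `COc1ccc(NC(=O)NCCNS(=O)(=O)c2ccc(-c3ccccc3OCc3ccccc3)s2)cc1`: > 50000 nM
Compound 2 `O=C(NCCNS(=O)(=O)c1ccc(-c2ccccc2OCc2ccccc2)s1)Nc1cccc([N+](=O)[O-])c1`: 13300 nM

The value for compound 1 is a limit and not a number. Compound 1 stands at the limit of > 50000 nM in this assay, at which 1 of the 2 values shown sits. Compound 3 `COc1ccc(NC(=O)NCCNS(=O)(=O)c2ccc(-c3ccccc3Oc3ccc([N+](=O)[O-])c([N+](=O)[O-])c3)s2)cc1` has not yet been measured. It departs from compound 1 in one place, with 3,4-dinitrophenyl in place of benzyl on an oxygen on an aromatic ring.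

For the measured compounds named here, only one measured step bears on this change, and only indirectly. That step is an at least 3.7-fold lower number from compound 1 to compound 2 (0.57 log units; beyond the scatter). Going by the values given here, it put 3-nitrophenyl in place of 4-methoxyphenyl on an amide-type nitrogen, which is a different place from the one changed in compound 3. Among the compounds with values here, it is still the only guide available, so a step of similar size towards a lower number is expected in this assay, and a result at the limit remains possible. The expected step is an at least 3.3-fold lower number from compound 1 to compound 3 (0.52 log units; beyond the scatter). For compound 3 the estimated value is 15000 nM. The expected range for compound 3 runs from 4000 nM to 50000 nM.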

Compound 3, half-maximal inhibitory concentration: 18500 nM
Compound 3: the middle estimate sits 1.2-fold (0.09 log units) below what was measured; the range from low to high includes it.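

In this assay, the group on the oxygen on an aromatic ring proves able to move the read-out: 3,4-dinitrophenyl in place of benzyl gives an at least 2.7-fold lower number from compound 1 to compound 3 (0.43 log units; beyond the scatter). The earlier compounds shown here showed a change only on the amide-type nitrogen, so this position is a second place in the molecule where a single change takes the number down, and compound 2 and compound 3 differ in more than one place, so their values cannot be set against each other directly. The value of compound 1 is a limit and not a number, so the step has only a lower bound and its full size stays unknown: the limit of > 50000 nM in this assay, at which 1 of the 3 values shown sits.

The compounds shown leave open whether the step belongs to the two nitro groups together, to one of them, or simply to the loss of benzyl, and how an unsubstituted phenyl, an amine or a carboxylic acid on this ring would read in this assay. They also leave open whether 3,4-dinitrophenyl on the oxygen and 3-nitrophenyl on the amide-type nitrogen would add up when carried by one molecule.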